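The source may report more compounds than this note shows. Statements on the series, on what has been measured and on what is new or still open speak of the compounds shown alone.

Measured in a functional assay on ACHN cells (Homo sapiens) for cytotoxicity, read by sulforhodamine B assay, with a stated time of 72 h; a lower number here means a stronger inhibitor of growth, a higher number a weaker inhibitor of growth:
- compound 1 `O=C(Nc1ccc(C(F)(F)F)cc1)C1CCc2ccccc2N1`: 25000 nM
- compound 2 `CC(=O)N1c2ccccc2CCC1C(=O)Nc1cc(C(F)(F)F)cc(C(F)(F)F)c1`: > 70000 nM (a limit)
- compound 3 `CCCC(=O)N1c2ccccc2CCC1C(=O)Nc1cc(C(F)(F)F)cc(C(F)(F)F)c1`: 13900 nM

The value of compound 2 is a limit, not a number. Compound 1 gives 25000 nM, and this lies within the scatter of compound 3 at 13900 nM. Compound 4 `O=C(Nc1ccc(O)cc1)C1CCc2ccccc2N1` has hydroxy in place of trifluoromethyl on an aromatic carbon, para to a large group: hydroxy in place of trifluoromethyl on an aromatic carbon. For the measured compounds named here, no measured step touches that carbon. The only one, an at least 5.0-fold lower number from compound 2 to compound 3 (0.70 log units; beyond the scatter), concerns a saturated chain carbon bound to a carbonyl carbon, so it shows only how far one change can move this assay. A small step towards a higher number is expected, possibly within the scatter: a 1.6-fold higher number from compound 1 to compound 4 (0.20 log units; within the scatter). For compound 4 the estimate is 40000 nM, with an expected range of 15000 nM to 100000 nM.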

Compound 4, concentration for 50% growth inhibition: > 100000 nM
Compound 4: a limit, no number; the forecaster's own chance of this, stated with the estimate: 35%; middle value at least 2.5-fold (0.39 log units) away from the limit.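

Hydroxy in place of trifluoromethyl on this aromatic carbon gives an at least 4.0-fold higher number from compound 1 to compound 4 (0.60 log units; beyond the scatter) in this assay. For the compounds shown here, the earlier step concerned only a saturated chain carbon, so this is the first sign that the aromatic carbon para to a large group also moves the read-out. The value of compound 4 is a limit, not a number, and the true size of the step stays unknown: the limit of > 100000 nM in this assay, at which 1 of the 4 values shown sits.

On these data alone, whether a methoxy group, an amine or a chlorine on this carbon would stay close to compound 1 remains open.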